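Working notes on a chloro step from compound 1

The source may hold more compounds than are shown below. What is called first, only, known or untested is meant among the compounds shown, and "the series" means these compounds.

Measured so far in a physicochemical assay for pharmacokinetics, at pH 8; on this read-out lower numbers stand for a shorter-lived compound and higher numbers for a longer-lived compound
- compound 1 `O=C(Sc1cccnc1C(=O)O)c1ccccc1` gives 60.1 h
- compound 2 `O=C(Sc1cccnc1C(=O)O)c1cccc(Cl)c1` gives 14.8 h

For the measured compounds named here, compound 1 holds the higher of these two numbers, and compound 2 is the only neighbour for comparison. The next compound to read in this assay is compound 3 `O=C(Sc1cccnc1C(=O)O)c1ccccc1Cl` which has not been measured yet. Its difference from compound 1 is chloro in place of hydrogen on an aromatic carbon and it puts chloro in place of hydrogen on the aromatic carbon ortho to a large group.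

Going by the values given here, the one measured step that bears on this is a 4.1-fold lower number from compound 1 to compound 2 (0.61 log units; beyond the scatter) which is modest and is the same exchange made at another carbon of that ring. Among the compounds with values here, no measured step shows a chloro at the new place, so the transfer is uncertain. A modest move to a lower number is therefore expected in this assay and it may well be smaller than the measured step. The estimated step is a 2.0-fold lower number from compound 1 to compound 3 (0.30 log units; within the scatter) as a working expectation. For compound 3 the expected value is 30 h with an estimated range from 9 h to 100 h in this series.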

Compound 3, half-life: 75.8 h
For compound 3 the middle estimate is 2.5-fold (0.40 log units) below the measured one; the range from low to high includes it.
By their numbers in this assay, from the lowest: compound 2; then compounds 1 and 3 (each within the scatter of the next).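

Read in this assay, chloro in place of hydrogen on the aromatic carbon ortho to a large group gives a 1.3-fold higher number from compound 1 to compound 3 (0.10 log units; within the scatter), so at this carbon the exchange stays inside the usual scatter. The same exchange at another carbon of that ring gives a 4.1-fold lower number from compound 1 to compound 2 (0.61 log units; beyond the scatter), which lies beyond the scatter, so the size of the chloro step in this series is not the same at every carbon of the ring, at least across these two pairs. No measurement at hand bears on what separates the two carbons.

Still open, on these data alone, is whether this carbon tolerates groups other than chloro, since a fluoro, a methoxy or an amine in the same place could read within the scatter of compound 1 or well away from it. Equally open, as far as these compounds go, is whether the step seen for compound 2 belongs to chloro alone or would recur with a methyl or a nitrile on that same carbon, which would show whether that carbon is sensitive to substitution in general.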